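This account rests on a few compounds, and the source may have more. Where it says the series, first, only, none or still open, it means among the compounds named here.

In a functional assay on PC-3 cells (Homo sapiens) for antiproliferative activity, read by CCK-8 assay, with a stated time of 6 days (on this read-out lower numbers stand for stronger inhibition and higher numbers for weaker inhibition), compound 1 `CCN(c1ccc(C#N)c(Cl)c1)c1cc(-c2cccnc2)ccc1C` gives 11000 nM. Compound 2 `CCN(c1ccc(C#N)c(Cl)c1)c1cc(-n2ccnc2)ccc1C` reaches only the assay limit of > 30000 nM, so for compound 2 a limit rather than a number is known (the limit of > 30000 nM in this assay, at which 1 of the 2 values shown sits). Compound 3 `CCN(c1ccc(C#N)c(Cl)c1)c1cc(-c2ccco2)ccc1C` differs from compound 2 by furan-2-yl in place of 1H-imidazol-1-yl on an aromatic carbon. For the measured compounds named here, the only measured step that bears on this is an at least 2.7-fold higher number from compound 1 to compound 2 (0.43 log units; beyond the scatter), where the 1H-imidazol-1-yl entered; its departure here is expected to turn that loss partly back, so from compound 2 to compound 3 a change of an at least 2.0-fold lower number from compound 2 to compound 3 (0.30 log units; that floor lies within the scatter) is expected in this assay. Compound 3 is therefore estimated at 15000 nM, between 6000 nM and 40000 nM.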

Compound 3, half-maximal inhibitory concentration: > 30000 nM
Compound 3 was reported as a limit; the forecaster's own chance of this, stated with the estimate: 35%; middle value at least 2.0-fold (0.30 log units) from the limit.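

In this assay compound 3 gives > 30000 nM, which is a limit and not a number. Furan-2-yl in place of pyridin-3-yl gives an at least 2.7-fold higher number from compound 1 to compound 3 (0.43 log units; beyond the scatter), so a second five-membered aromatic ring also fails to match compound 1, and the furan-2-yl brings no measurable recovery. The step between compound 2 and compound 3 cannot be read: the limit of > 30000 nM in this assay, at which 2 of the 3 values shown sit.

On these data alone, how far compound 2 and compound 3 lie past that limit remains open. So does whether a phenyl or pyridin-4-yl group, or a pyridin-3-yl carrying an amine, would improve on compound 1.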